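The source may report more compounds than this note shows. Statements on the series, on what has been measured and on what is new or still open speak of the compounds shown alone.

Compound 1 `COc1cccc(CNc2ncnc3c2ncn3[C@@H]2O[C@H](CO)[C@@H](O)[C@H]2O)c1`: > 166000 nM in a functional assay on K562 cells (Homo sapiens) for antiproliferative activity, with a stated time of 72 h; a lower number here means a stronger inhibitor, a higher number a weaker inhibitor (a limit, not a number)
Compound 2 `OC[C@H]1O[C@@H](n2cnc3c(NCc4ccc(Cl)c(Cl)c4)ncnc32)[C@H](O)[C@@H]1O`: 10800 nM in this assay

Among the measured compounds shown here, compound 2 holds the only true number so far in this assay, at 10800 nM. Compound 1 gives only a limit, (the limit of > 166000 nM in this assay, at which 1 of the 2 values shown sits).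

Compound 3 `OC[C@H]1O[C@@H](n2cnc3c(NCc4ccc(F)cc4F)ncnc32)[C@H](O)[C@@H]1O` keeps the shared core and differs from compound 2 in one place: 2,4-difluorophenyl in place of 3,4-dichlorophenyl on a saturated chain carbon bound to a nitrogen on an aromatic ring. Put simply, it has 2,4-difluorophenyl in place of 3,4-dichlorophenyl on a saturated chain carbon bound to a nitrogen on an aromatic ring.

For the measured compounds named here, one measured step bears on this change: an at least 15-fold lower number from compound 1 to compound 2 (1.18 log units; beyond the scatter). This large step, at the same place, shows that the group there can matter greatly in this assay. It does not involve 2,4-difluorophenyl, however, so it is only a rough guide. Going by the values given here, compound 3 gives up the group present in compound 2, the only compound with a measured number, so a weaker result is expected, probably beyond the scatter but smaller than that first step.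

The expected change is a 3.7-fold higher number from compound 2 to compound 3 (0.57 log units; beyond the scatter).

For compound 3 the estimated value is 40000 nM, with an expected range from 9000 nM to 166000 nM.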

Compound 3, half-maximal inhibitory concentration: 9600 nM
Compound 3: the middle estimate sits 4.2-fold (0.62 log units) above what was measured; the measured number falls inside the stated range.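

Replacing 3,4-dichlorophenyl with 2,4-difluorophenyl on a saturated chain carbon bound to a nitrogen on an aromatic ring leaves the result in this assay essentially unchanged: a 1.1-fold lower number from compound 2 to compound 3 (0.05 log units; within the scatter). The other new step is also large, an at least 17-fold lower number from compound 1 to compound 3 (1.23 log units; beyond the scatter), so among these three compounds, both the chlorine-bearing and the fluorine-bearing phenyl groups stand apart from the 3-methoxyphenyl group of compound 1, and the activity of compound 2 does not depend on 3,4-dichlorophenyl alone. Compound 1 gives only a limit, so the true size of both large steps remains unknown: the limit of > 166000 nM in this assay, at which 1 of the 3 values shown sits.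

The step from 3,4-dichlorophenyl to 2,4-difluorophenyl changes both the halogen and the ring pattern, and the two may offset each other or may each have little effect, so 3,4-difluorophenyl or 2,4-dichlorophenyl would be needed to separate them. Going by these compounds, it also remains open whether a different group at this place, such as an unsubstituted phenyl, a pyridine ring or a carboxylic acid, would keep this level of activity or move the number much lower.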